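The source may report more compounds than this note shows. Statements on the series, on what has been measured and on what is new or still open speak of the compounds shown alone.

Measured so far:
Compound 1, `CC1=CC[C@H](C(C)(C)N=C=S)CC1`. In a functional assay on K562 cells (Homo sapiens) for inhibition, read by sulforhodamine B assay, with a stated time of 48 h (a lower number here means a stronger inhibitor of growth, a higher number a weaker inhibitor of growth), compound 1 gives > 100000 nM, which is a limit of the assay.
Compound 2, `CC1=CC[C@H](C(C)(C)NC(=S)N/N=C/c2ccccc2O)CC1`. In this assay compound 2 gives > 100000 nM, again a limit.
Compound 3, `CC1=CC[C@H](C(C)(C)NC(=S)N/N=C/c2ccccc2[N+](=O)[O-])CC1`. In this assay compound 3 gives > 100000 nM, also a limit.

Compound 2 therefore stands at the limit, together with every other compound measured here: the limit of > 100000 nM in this assay, at which 3 of the 3 values shown sit. For the measured compounds named here, the one comparison available, from compound 2 to compound 3, a step that the two limits leave unreadable from compound 2 to compound 3, so it gives no readable size.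

Compound 4, `CC1=CC[C@H](C(C)(C)NC(=S)N/N=C/c2ccc[nH]2)CC1`, differs from compound 2 in a single place: 1H-pyrrol-2-yl in place of 2-hydroxyphenyl on a carbon with a double bond to nitrogen. Going by the values given here, no measured step shows what such a change does in this assay. With all three values resting at the limit, compound 4 is expected to sit there as well, a step of a number no higher from compound 2 to compound 4 (the limit leaves the size open). The estimate for compound 4 in this assay is 100000 nM, between 30000 nM and 300000 nM.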

Compound 4, concentration for total growth inhibition: > 100000 nM
Compound 4 was reported as a limit (the forecaster's own chance of this, stated with the estimate: 75%); the middle value sits exactly at the limit.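

Compound 4, like compound 2, rests at a limit in this assay, so the swap of 2-hydroxyphenyl for 1H-pyrrol-2-yl gives no readable step: the limit of > 100000 nM in this assay, at which 4 of the 4 values shown sit.

The compounds shown leave open what change, if any, would bring a value inside the assay's range.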